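Swapping the Aryl Tail: From Trimethoxyphenyl to Indole

This account rests on a few compounds, and the source may have more. Where it says the series, first, only, none or still open, it means among the compounds named here.

Measured so far:
compound 1 `CC(C)C[C@H](N)c1cc(C(F)(F)F)ccc1N1CCN(C(=O)CCc2c(Cl)cccc2Cl)CC1` gives 2600 nM
compound 2 `COc1cc(OC)c(OC)cc1CCC(=O)N1CCN(c2ccc(C(F)(F)F)cc2[C@@H](N)CC(C)C)CC1` gives 6100 nM

In an assay on HEK293 cells for displacement of a labelled ligand from Melanocortin receptor 4 (Homo sapiens) (a lower number here means a stronger inhibitor, a higher number a weaker inhibitor), compound 2 stands at the higher of the two numbers, separated from compound 1 by the step of a 2.3-fold higher number from compound 1 to compound 2 (0.37 log units; beyond the scatter). Compound 3 `CC(C)C[C@H](N)c1cc(C(F)(F)F)ccc1N1CCN(C(=O)CCc2c[nH]c3ccccc23)CC1` differs from compound 2 by 1H-indol-3-yl in place of 2,4,5-trimethoxyphenyl on a saturated chain carbon, two bonds along the chain from a carbonyl carbon. No measured step covers this exchange; the one step shown, a 2.3-fold higher number from compound 1 to compound 2 (0.37 log units; beyond the scatter), says only that the trimethoxyphenyl tail bound more weakly than the dichlorophenyl one. The expectation is that compound 3 returns toward the range of compound 1, a step of a 2.0-fold lower number from compound 2 to compound 3 (0.31 log units; beyond the scatter) to a lower number, modest but beyond the scatter, with wide uncertainty. The estimate for compound 3 is 3000 nM, between 900 nM and 10000 nM.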

Compound 3, inhibition constant: 640 nM
The estimate for compound 3 lay 4.7-fold (0.67 log units) above the measured number; the measured number lies below the stated range.
By their numbers in this assay, from the lowest: compound 3; then compound 1; then compound 2.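

In this assay, going by these compounds alone, the group on this saturated chain carbon, two bonds along the chain from a carbonyl carbon, can shift binding further than the first pair of compounds showed. The 1H-indol-3-yl group beats both other tails, with one step against 2,4,5-trimethoxyphenyl (a 9.5-fold lower number from compound 2 to compound 3 (0.98 log units; beyond the scatter)) and another against 2,6-dichlorophenyl (a 4.1-fold lower number from compound 1 to compound 3 (0.61 log units; beyond the scatter)). Nothing available explains this gain.

Going by these compounds, it remains open whether the hydrogen on the indole nitrogen matters, which a 1-methyl-1H-indol-3-yl tail would test. Also open, on these data alone, is how a longer chain to the indole would fare.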